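From Difluorocyclohexyl to Dimethylcyclohexenyl on the Shared Core

The source may report more compounds than this note shows. Statements on the series, on what has been measured and on what is new or still open speak of the compounds shown alone.

Of the compounds shown here, three with a shared core have been measured in an assay on CHO cells for antagonist activity at transient receptor potential cation channel subfamily V member 1 (Homo sapiens), read by FLIPR and calcium flux; on this read-out lower numbers stand for stronger inhibition and higher numbers for weaker inhibition. Compound 1 `CCCCCc1nc(C(F)(F)F)ccc1CNC(=O)C(C)c1ccc(NS(C)(=O)=O)c(F)c1` gives 1 nM in this assay. Compound 2 `CC(C(=O)NCc1ccc(C(F)(F)F)nc1C1CCC(F)(F)CC1)c1ccc(NS(C)(=O)=O)c(F)c1` gives 1.5 nM in this assay, and compound 3 `C[C@H](C(=O)NCc1ccc(C(F)(F)F)nc1C1=CCC(C(C)(C)C)CC1)c1ccc(NS(C)(=O)=O)c(F)c1` gives 0.1 nM in this assay. Compound 2 stands at the highest of the three numbers; compound 1 is nearest, and the step of a 1.5-fold higher number from compound 1 to compound 2 (0.18 log units; within the scatter) lies within the scatter, while compound 3 stands furthest away, beyond the scatter.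

Compound 4 `CC(C(=O)NCc1ccc(C(F)(F)F)nc1C1=CCC(C)(C)CC1)c1ccc(NS(C)(=O)=O)c(F)c1` has not yet been measured. It differs from compound 2 in one place: 4,4-dimethylcyclohex-1-en-1-yl in place of 4,4-difluorocyclohexyl on an aromatic carbon. Among the measured compounds shown here, no measured step matches this exchange. The step of a 1.5-fold higher number from compound 1 to compound 2 (0.18 log units; within the scatter) concerns the same position and was small. For the measured compounds named here, compound 3, which carries a cyclohexenyl group at the same position, shows a markedly lower number than compound 2, although no single-change step connects them. Compound 4 is therefore expected to land between them, with an estimated step of a 3.8-fold lower number from compound 2 to compound 4 (0.57 log units; beyond the scatter) in this assay. Compound 4 is estimated at 0.4 nM, with a range from 0.1 nM to 1.5 nM.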

Compound 4, inhibition constant: 0.2 nM
Compound 4: the middle estimate sits 2.0-fold (0.30 log units) above what was measured, within the range that was stated.
By their numbers in this assay, from the lowest: compounds 3 and 4 (each within the scatter of the next); then compounds 1 and 2 (each within the scatter of the next).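

In this assay, 4,4-dimethylcyclohex-1-en-1-yl in place of 4,4-difluorocyclohexyl gives a 7.5-fold lower number from compound 2 to compound 4 (0.88 log units; beyond the scatter) and thus a step at this position that lies beyond the scatter, which the earlier exchange of pentyl for 4,4-difluorocyclohexyl did not give. The same group in place of pentyl gives a 5.0-fold lower number from compound 1 to compound 4 (0.70 log units; beyond the scatter) and so shows that 4,4-dimethylcyclohex-1-en-1-yl stands apart from both of the other groups at this position on the shared core. Nothing available here accounts for these steps.

The exchange alters the ring's double bond and swaps fluorine for methyl groups at once, so the compounds shown do not say which of these changes carries the step. Going by these compounds, how a saturated 4,4-dimethylcyclohexyl or a phenyl group would stand at this position remains open.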